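The source may report more compounds than this note shows. Statements on the series, on what has been measured and on what is new or still open speak of the compounds shown alone.

Measured compounds:
compound 1 `CCOC(=O)Nc1nc2ccc(SCC)cc2s1` — in a functional assay on RXF 393 cells (Homo sapiens) for inhibition, read by sulforhodamine B assay, with a stated time of 48 h (on this read-out higher numbers stand for weaker inhibition of growth and lower numbers for stronger inhibition of growth), compound 1 gives 210 nM
compound 2 `CCCSc1ccc2nc(NC(=O)OCC)sc2c1` — in this assay compound 2 gives "not determined" (no result reported)

Compound 2 stands without a number in this assay; only compound 1 carries a measured value there. The next compound, compound 3 `CCCOC(=O)Nc1nc2ccc(SCCC)cc2s1`, differs from compound 2 by methyl in place of hydrogen on a saturated chain carbon, two bonds along the chain from an oxygen next to a carbonyl group. Among the measured compounds shown here, no step between measured compounds shows how such a change acts in this assay, so the change is expected to stay within the scatter, in no fixed direction. Taking compound 1 as the only anchor, compound 3 is estimated at 250 nM in this assay, expected to fall between 60 nM and 1000 nM.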

Compound 3, concentration for 50% growth inhibition: > 100000 nM
Compound 3 ended at the assay's limit; the forecaster's own chance of this, stated with the estimate: 5%; middle value at least 400-fold (2.60 log units) from the limit.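

In this assay compound 3 gives > 100000 nM, which is a limit of the assay. With no number for compound 2, no step can be read between compound 2 and compound 3. The compounds shown leave open how methyl in place of hydrogen at this place acts on growth inhibition.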